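A few compounds are considered here, and "the series" means these few. Any claim that something is new, unique, unknown or untested is made for them only; others in the source may bear on it.

Measured so far in a functional assay on MDA-MB-231 cells (Homo sapiens) for cytotoxicity, read by MTT assay, with a stated time of 72 h; on this read-out higher numbers stand for weaker inhibition and lower numbers for stronger inhibition:
- compound 1 `CCN(CC)CCCNc1nc(-c2ccc(NC(=O)Nc3ccc(Cl)cc3)cc2)nc2ccsc12`: 230 nM
- compound 2 `CCN(CC)CCCNc1nc(-c2ccc(NC(=O)Nc3ccccc3Cl)cc2)nc2ccsc12`: 500 nM

For the measured compounds named here, compound 2 gives the highest of the two numbers in this assay; its only neighbour is compound 1, and the single measured step, a 2.2-fold higher number from compound 1 to compound 2 (0.34 log units; beyond the scatter), is modest but beyond the scatter. The shared core and the diethylaminopropylamino chain are untouched in both.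

Compound 3 `CCN(CC)CCCNc1nc(-c2ccc(NC(=O)Nc3ccc(C)cc3)cc2)nc2ccsc12` is not yet measured. It differs from compound 2 by 4-methylphenyl in place of 2-chlorophenyl on an amide-type nitrogen. Going by the values given here, only one measured step bears on this: a 2.2-fold higher number from compound 1 to compound 2 (0.34 log units; beyond the scatter), which moved the chlorine from the 4-chlorophenyl of compound 1 to the 2-chlorophenyl of compound 2 and raised the number modestly. Among the compounds with values here, compound 3 carries a 4-methylphenyl, the same substitution pattern as the 4-chlorophenyl of compound 1, but no measured pair in this set compares methyl with chlorine, so that part of the change is unanchored. The step of a 1.8-fold lower number from compound 2 to compound 3 (0.25 log units; within the scatter) is therefore expected to run back toward compound 1, modest in size, with the methyl-for-chlorine part adding uncertainty. For compound 3 the estimate in this assay is 280 nM, within a range from 120 nM to 650 nM.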

Compound 3, half-maximal inhibitory concentration: 1980 nM
The estimate for compound 3 lay 7.1-fold (0.85 log units) below the measured number; the measured number lies above the stated range.
By their numbers in this assay, from the lowest: compound 1; then compound 2; then compound 3.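

In this assay, for the compounds shown here, an 8.6-fold higher number from compound 1 to compound 3 (0.93 log units; beyond the scatter) gives the first direct comparison of methyl with chloro on an aromatic carbon, with the 4-substituted phenyl pattern kept, and this exchange costs more than the change from 4-chlorophenyl to 2-chlorophenyl, a 2.2-fold higher number from compound 1 to compound 2 (0.34 log units; beyond the scatter) on the same read-out. With a 4.0-fold higher number from compound 2 to compound 3 (0.60 log units; beyond the scatter) as well, the 4-methylphenyl on the amide-type nitrogen does not return the series toward compound 1 but gives the weakest inhibition of the three, with its steps to both others beyond the scatter. Across these three compounds, then, the identity of the group on this ring separates the numbers more than the place of the chlorine does, and both chlorine-bearing compounds stay on the stronger side, with no compound here going against that.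

Unsubstituted phenyl would show whether the loss of chlorine or the arrival of methyl drives the step, and 2-methylphenyl or 4-methoxyphenyl would test how far the pattern reaches. Nothing at hand offers an explanation for the size of this step.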